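This account rests on a few compounds, and the source may have more. Where it says the series, first, only, none or still open, it means among the compounds named here.

Measured so far:
compound 1 `Cn1ncc2c(=O)n(-c3ccccc3)c(CNc3cccc(F)c3)nc21`: 570 nM
compound 2 `CC(Sc1nc2c(cnn2C)c(=O)n1-c1ccccc1)c1ccccc1`: 130 nM
compound 3 `Cn1ccc2c(=O)n(-c3ccccc3)c(SCc3cccc(F)c3)nc21`: 930 nM

These three compounds were tested in an assay on isolated protein for inhibition of aldehyde dehydrogenase 1A1 (Homo sapiens); on this read-out higher numbers stand for weaker inhibition and lower numbers for stronger inhibition. Compound 1 stands second highest of the three numbers; its nearest neighbour is compound 3, whose number lies within the scatter of it, while compound 2 gives a number well beyond the scatter below it. Among the measured compounds shown here, no two of them differ in only one place, so no single step between measured compounds can be read off.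

Compound 4 `Cn1ncc2c(=O)n(-c3ccccc3)c(CCc3cccc(F)c3)nc21` has not yet been measured. It differs from compound 1 in one place: 3-fluorobenzyl in place of (3-fluorophenyl)amino on a saturated chain carbon bound to an aromatic carbon. The change keeps the ring and the count of heavy atoms, but the hydrogen-bond donor and acceptor of the (3-fluorophenyl)amino group are gone. For the measured compounds named here, with no matching step among the measured compounds, the expectation for the step from compound 1 to compound 4 in this assay is a small one, if any, probably toward a weaker number, a 1.4-fold higher number from compound 1 to compound 4 (0.15 log units; within the scatter). Compound 4 is therefore estimated at 800 nM, within a range from 300 nM to 2500 nM.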

Compound 4, half-maximal inhibitory concentration in the aldehyde dehydrogenase 1A1 assay: 1000 nM
Estimate against measurement, compound 4: 1.3-fold (0.10 log units) below; low and high end bracket the measured number.
By their numbers in the aldehyde dehydrogenase 1A1 assay, from the lowest: compound 2; then compounds 1, 3 and 4 (each within the scatter of the next).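

At this place on the saturated chain carbon, 3-fluorobenzyl in place of (3-fluorophenyl)amino gives in the aldehyde dehydrogenase 1A1 assay (a 1.8-fold higher number from compound 1 to compound 4 (0.24 log units; within the scatter)), so losing the hydrogen-bond donor and acceptor of that group produces no step beyond the scatter. In a physicochemical assay for solubility, using the shake flask method, in phosphate buffer, with a stated time of 24 h, at pH 7.4 (a higher number here means a more soluble compound, a lower number a less soluble compound), compound 1 gives 64000 nM and compound 4 gives 126000 nM (a 2.0-fold higher number from compound 1 to compound 4 (0.29 log units; within the scatter)), so this read-out also shows no step beyond the scatter. Nothing available explains either step. On these data alone, how a carboxylic acid, an ether or a longer chain at this place would read in the aldehyde dehydrogenase 1A1 assay or in the physicochemical assay remains open.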